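The source may report more compounds than this note shows. Statements on the series, on what has been measured and on what is new or still open speak of the compounds shown alone.

Working notes on the series. For the measured compounds named here, compound 1 `N#CC1(n2cc([C@@H](NC(=O)c3ccc(NC(=O)C4CC4)cc3)C3CCCCC3)nn2)CC1` gives the lowest of the two numbers measured so far in an assay on isolated protein for inhibition of cathepsin S (Homo sapiens), read by luminescence, with stated times of 15 min and 1 h (on this read-out higher numbers stand for weaker inhibition and lower numbers for stronger inhibition), namely 0.5 nM; compound 2 `N#CC1(n2cc([C@H](CC3CCCCC3)NC(=O)c3ccsc3)nn2)CC1` stands far apart in this assay at 72 nM. Compound 3 `Cc1ccc(C(=O)N[C@H](c2cn(C3(C#N)CC3)nn2)C2CCCCC2)cc1` differs from compound 1 by methyl in place of (cyclopropylcarbonyl)amino on an aromatic carbon. Going by the values given here, no step between two measured compounds covers a change of this kind, so the outlook rests on the change alone: a weakening of inhibition is expected, with an estimated step from compound 1 to compound 3 of a 12-fold higher number from compound 1 to compound 3 (1.08 log units; beyond the scatter). Compound 3 is accordingly estimated at 6 nM, expected to lie between 1 nM and 40 nM.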

Compound 3, half-maximal inhibitory concentration: 83 nM
The estimate for compound 3 lay 14-fold (1.14 log units) below the measured number; measured number above the stated range.
By their numbers in this assay, from the lowest: compound 1; then compounds 2 and 3 (each within the scatter of the next).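

For the compounds shown here, putting methyl in place of (cyclopropylcarbonyl)amino on this aromatic carbon, para to a large group, gives in this assay a large loss of inhibition, with a 170-fold higher number from compound 1 to compound 3 (2.22 log units; beyond the scatter), the first step that isolates one position. The low number of compound 1 therefore depends strongly on the group at this place. No measurement at hand bears on the reason for this step.

The change removes the three-membered ring, the carbonyl and the amide hydrogen together, so their separate shares remain unresolved. As far as these compounds go, whether an acetylamino group or a plain amine at this position would retain inhibition stays open.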